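Chalcone anilides: varying the benzoyl ring substitution

The source may hold more compounds than are shown below. What is called first, only, known or untested is meant among the compounds shown, and "the series" means these compounds.

Measured so far:
compound 1 `COc1cc(/C=C/C(=O)c2cccc(NC(=O)c3c(Cl)cccc3Cl)c2)ccc1O` — 0.46 ug/mL
compound 2 `COc1cc(/C=C/C(=O)c2cccc(NC(=O)c3ccc(Cl)c(Cl)c3)c2)ccc1O` — 2.97 ug/mL

In a functional assay on HUVEC cells (Homo sapiens) for inhibition (on this read-out higher numbers stand for weaker inhibition and lower numbers for stronger inhibition), compound 1 gives the lowest of the two numbers. Compound 2 stands above it: a 6.5-fold higher number from compound 1 to compound 2 (0.81 log units; beyond the scatter). Compound 3 `COc1cc(/C=C/C(=O)c2cccc(NC(=O)c3ccccc3)c2)ccc1O` carries a change at the same place: phenyl in place of 2,6-dichlorophenyl on a carbonyl carbon. For the measured compounds named here, no measured step removes both chlorines outright; the only step that bears on it is the one from compound 1 to compound 2, where a changed chlorine pattern on that ring gave a modest rise. A rise of similar size is therefore expected here, a 4.3-fold higher number from compound 1 to compound 3 (0.64 log units; beyond the scatter), giving an estimated 2 ug/mL for compound 3, within 0.6 ug/mL to 6.5 ug/mL.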

Compound 3, half-maximal inhibitory concentration: 0.37 ug/mL
Compound 3: the middle estimate sits 5.4-fold (0.73 log units) above what was measured; measured number below the stated range.
By their numbers in this assay, from the lowest: compounds 3 and 1 (each within the scatter of the next); then compound 2.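

Phenyl and 2,6-dichlorophenyl on the carbonyl carbon read alike in this assay, with a 1.2-fold lower number from compound 1 to compound 3 (0.09 log units; within the scatter), so chlorine on this ring is not needed for a low number. Compound 2 alone stands apart, with an 8.0-fold lower number from compound 2 to compound 3 (0.90 log units; beyond the scatter), which places the 3,4-dichlorophenyl group rather than chlorine as such at the high end among these three compounds. Nothing at hand accounts for this difference.

Still open, as far as these compounds go, is whether a ring with a single chlorine follows phenyl or 3,4-dichlorophenyl. From the compounds shown here alone, how a methoxy group or an amine on this ring would read also remains open.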